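A few compounds are considered here, and "the series" means these few. Any claim that something is new, unique, unknown or untested is made for them only; others in the source may bear on it.

Going by the values given here, compound 3, `CCCNc1cc(NC(=O)c2cccnc2)cc(C(F)(F)F)c1`, is the one member of this small set that yields a measurable number: in an assay on HEK293-TREx cells for antagonist activity at transient receptor potential cation channel subfamily A member 1 (Homo sapiens), read by calcium flux (a higher number here means a weaker inhibitor, a lower number a stronger inhibitor), compound 3 gives 940 nM. Its two companions stop at the assay limit. Compound 1, `CCCN(CCC)c1cc(NC(=O)c2cccs2)cc(C(F)(F)F)c1`, returns only a limit in this assay, > 32000 nM. Compound 2, `CCCNc1cc(NC(=O)c2ccccn2)cc(C(F)(F)F)c1`, likewise returns only a limit in this assay, > 32000 nM. Among the compounds with values here, the one measured step that touches the aromatic group on the carbonyl carbon is large: an at least 34-fold lower number from compound 2 to compound 3 (1.53 log units; beyond the scatter), which shows how sharply this assay responds to a change of the ring in that place, consistent with the limit of > 32000 nM in this assay, at which 2 of the 3 values shown sit, where compound 1 and compound 2 both sit. Compound 4, `CCCNc1cc(NC(=O)c2ccc(F)cc2)cc(C(F)(F)F)c1`, differs from compound 3 by 4-fluorophenyl in place of pyridin-3-yl on a carbonyl carbon. Within the data shown here, no measured step pairs a six-membered carbon-only ring against the pyridin-3-yl ring, so the direction cannot be read from the data; the measured step only warns that the change may be large either way. The estimate for compound 4 is therefore centred on the value of compound 3 with a wide band: compound 4 is expected to give 1200 nM in this assay, between 200 nM and 8000 nM, a step of a 1.3-fold higher number from compound 3 to compound 4 (0.11 log units; within the scatter) that is expected to be modest.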

Compound 4, half-maximal inhibitory concentration: 1400 nM
Beside the measured number, compound 4's estimate is 1.2-fold (0.07 log units) below it; the range from low to high includes it.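

Exchanging pyridin-3-yl for 4-fluorophenyl on the carbonyl carbon gives a 1.5-fold higher number from compound 3 to compound 4 (0.17 log units; within the scatter) in this assay, so a ring of carbon only serves this position as well as the pyridin-3-yl ring, and a ring nitrogen is not needed for a measurable number. Against pyridin-2-yl, the same group gives an at least 22-fold lower number from compound 2 to compound 4 (1.35 log units; beyond the scatter), so two different rings now stand clear of compound 2, which makes the pyridin-2-yl ring the exception among these three compounds. The true size of that step stays unknown, as it rests on a limit: the limit of > 32000 nM in this assay, at which 2 of the 4 values shown sit.

The compounds shown leave open what the fluorine contributes, as plain phenyl or 4-chlorophenyl on the carbonyl carbon would be needed to separate it from the ring change. They also leave open whether a ring bearing an amine or a carboxylic acid would hold this level.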